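Swapping Phenyl for Chloro on the Exocyclic Chain

The compounds below may be only part of what the source reports. "The series", "measured", "known", "first", "only" and "open" are said of these compounds alone.

Compound 3 `CC1=C/C(=C\c2ccccc2)C(=O)C(C)(O)C12CC2` gives 1500 nM in a functional assay on A549 cells (Homo sapiens) for antiproliferative activity (a lower number here means a stronger inhibitor, a higher number a weaker inhibitor), the highest number of the three measured compounds and so the weakest inhibitor. Compound 1 `CC1=C/C(=C\C(C)C)C(=O)C(C)(O)C12CC2` gives 110 nM in this assay, and compound 2 `C/C=C1\C=C(C)C2(CC2)C(C)(O)C1=O` gives 150 nM. The change to compound 4 `CC1=C/C(=C\Cl)C(=O)C(C)(O)C12CC2` is chloro in place of phenyl on a double-bonded chain carbon bound to a double-bonded ring carbon. Among the measured compounds shown here, two measured steps bear on it: a 14-fold higher number from compound 1 to compound 3 (1.13 log units; beyond the scatter) and a 10-fold higher number from compound 2 to compound 3 (1.00 log units; beyond the scatter), both beyond the scatter and both showing that bringing in the six-atom phenyl raised the number sharply. Chloro brings one heavy atom where phenyl brought six, so a move back toward the lower numbers is expected. Compound 4 is therefore estimated at 300 nM, within a range of 80 nM to 1500 nM. This estimate corresponds to a 5.0-fold lower number from compound 3 to compound 4 (0.70 log units; beyond the scatter).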

Compound 4, half-maximal inhibitory concentration: 200 nM
Estimate against measurement, compound 4: 1.5-fold (0.18 log units) above; measured number inside the range.
By their numbers in this assay, from the lowest: compounds 1, 2 and 4 (each within the scatter of the next); then compound 3.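

In this assay the high number belongs to phenyl and not to every group at this place: there is a 7.5-fold lower number from compound 3 to compound 4 (0.88 log units; beyond the scatter) and the shared core recovers with chloro. Both a 1.3-fold higher number from compound 2 to compound 4 (0.12 log units; within the scatter) and a 1.8-fold higher number from compound 1 to compound 4 (0.26 log units; within the scatter) stay within the scatter, so chloro, methyl and isopropyl cannot be told apart here. Nothing measured explains why phenyl stands out. Still open, from the compounds shown here alone, is whether a longer chain, an amine or a carboxylic acid on this chain carbon would keep the number as low as chloro does.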